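Series notes: amine side-chain exchange on a shared core

A few compounds are considered here, and "the series" means these few. Any claim that something is new, unique, unknown or untested is made for them only; others in the source may bear on it.

Measured so far:
Compound 1 `CC(C)Sc1nnc(-c2c(CNc3nc4ccccc4[nH]3)c3ccccc3n2C)n1-c1ccccc1` gives 5.94 in a physicochemical assay for lipophilicity; on this read-out lower numbers stand for lower lipophilicity and higher numbers for higher lipophilicity.
Compound 2 `COCCNCc1c(-c2nnc(SC(C)C)n2-c2ccccc2)n(C)c2ccc(F)cc12` gives 4.52 in this assay.

For the measured compounds named here, compound 1 holds the highest of the two numbers so far; compound 2 sits lower, and the gap between the two is beyond the scatter. Going by the values given here, compound 1 and compound 2 differ in more than one place, so no single step is read from that pair.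

Compound 3 `CC(C)Sc1nnc(-c2c(CNCCN3CCCC3)c3ccccc3n2C)n1-c1ccccc1` is not yet measured. It differs from compound 1 in one place: 2-(pyrrolidin-1-yl)ethyl in place of 1H-benzimidazol-2-yl on an amine nitrogen. Among the compounds with values here, no step between measured compounds matches this change, so the expectation rests on the structural change alone and on where compound 1 stands. For compound 3 a downward step a number 1.04 log units lower from compound 1 to compound 3 (beyond the scatter) in this assay is expected, beyond the scatter but leaving it above compound 2. Compound 3 is estimated at 4.9, with a range from 4.2 to 5.6.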

Compound 3, partition coefficient: 4.83
Compound 3: middle estimate off by 0.07 log units, on the high side, and the stated range covers the measured number.
By their numbers in this assay, from the lowest: compound 2; then compound 3; then compound 1.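

Read in this assay, 2-(pyrrolidin-1-yl)ethyl in place of 1H-benzimidazol-2-yl on the amine nitrogen gives a number 1.11 log units lower from compound 1 to compound 3 (beyond the scatter). For the compounds shown here, this is the first step read with the rest of the structure held constant, and it shows that this position alone can shift the read-out beyond the scatter, which the pair of compound 1 and compound 2 could not show. No available evidence bears on why the number falls with this change.

The compounds shown leave open whether the step follows the loss of the aromatic rings of 1H-benzimidazol-2-yl or the arrival of the pyrrolidine ring on its chain. A phenyl group or a 2-(morpholin-4-yl)ethyl group on the same amine nitrogen would help to separate these two readings.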